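A few compounds are considered here, and "the series" means these few. Any claim that something is new, unique, unknown or untested is made for them only; others in the source may bear on it.

Compound 2, `COc1cccc(S(=O)(=O)c2cccc3oc(N4CCNCC4)nc23)c1`, and compound 1, `O=S(=O)(c1cccc(F)c1)c1cccc2oc(N3CCNCC3)nc12`, share one core and differ only in the group on the aromatic ring attached to the sulfonyl sulfur. Within the data shown here, in an assay on HeLa cells for displacement of a labelled ligand from 5-hydroxytryptamine receptor 6 (Homo sapiens) (on this read-out higher numbers stand for weaker inhibition and lower numbers for stronger inhibition), compound 1 gives 54 nM, while compound 2 gives 25 nM, the lowest of the two numbers; the single measured step, a 2.2-fold lower number from compound 1 to compound 2 (0.33 log units; beyond the scatter), shows that the substituent on that ring does move the number. Compound 3, `O=S(=O)(c1cc(Cl)ccc1Cl)c1cccc2oc(N3CCNCC3)nc12`, carries 2,5-dichlorophenyl in place of 3-methoxyphenyl on a sulfonyl sulfur. Among the measured compounds shown here, no measured step covers this exchange; the one step that touches the same ring is modest and bears on it only loosely. The range of the two numbers is therefore the best guide, and compound 3 is expected to land near them, with a step of a 1.6-fold higher number from compound 2 to compound 3 (0.20 log units; within the scatter) in this assay, a change that may well stay within the scatter. The estimate for compound 3 in this assay is 40 nM, between 12 nM and 130 nM.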

Compound 3, inhibition constant: 13 nM
Estimate against measurement, compound 3: 3.1-fold (0.49 log units) above; the measured number falls inside the stated range.
By their numbers in this assay, from the lowest: compounds 3 and 2 (each within the scatter of the next); then compound 1.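

In this assay, putting 2,5-dichlorophenyl in place of 3-fluorophenyl on the sulfonyl sulfur gives a 4.2-fold lower number from compound 1 to compound 3 (0.62 log units; beyond the scatter) and is the largest step seen so far at this position. Putting it in place of 3-methoxyphenyl gives a 1.9-fold lower number from compound 2 to compound 3 (0.28 log units; within the scatter) and so leaves compound 2 and compound 3 indistinguishable in this read-out. The position therefore accepts two quite different rings at a similar level, one with a hydrogen-bond acceptor and one with two chlorine atoms and no acceptor, so that acceptor is not required to reach this level. No measurement shown here explains these differences. Going by these compounds, whether a single chlorine would give the same number, and which of the two chlorine atoms matters more, stays open. So does the behaviour of this position with an amine, a carboxylic acid or a longer chain on the ring.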